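This account rests on a few compounds, and the source may have more. Where it says the series, first, only, none or still open, it means among the compounds named here.

Series notes, HeLa growth inhibition.

Compound 1 `O=C(Nc1cnn(-c2ccccc2)c1)c1cccc(NS(=O)(=O)c2ccccc2)c1` pairs a phenyl-substituted pyrazole amide with a benzenesulfonamide on the benzamide ring. In a functional assay on HeLa cells (Homo sapiens) for inhibition, read by MTT assay, with a stated time of 48 h (on this read-out higher numbers stand for weaker inhibition and lower numbers for stronger inhibition), compound 1 gives 15300 nM. Compound 2 `Cc1ccc(-n2cc(NC(=O)c3cccc(NS(=O)(=O)c4ccccc4)c3)cn2)cc1` carries the change (methyl in place of hydrogen on an aromatic carbon). In this assay, going by the values given here, compound 2 gives 3120 nM, and the step of a 4.9-fold lower number from compound 1 to compound 2 (0.69 log units; beyond the scatter) is the only measured instance of this change.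

Compound 3 `O=C(Nc1cnn(-c2ccccc2)c1)c1ccc(NS(=O)(=O)c2ccccc2)cc1` has the same atoms as compound 1 joined differently; the difference between the two cores is not broken down here. In this assay compound 3 gives 37100 nM, the highest of the three numbers, beyond the scatter from both compound 1 and compound 2.

Compound 4 `Cc1ccc(-n2cc(NC(=O)c3ccc(NS(=O)(=O)c4ccccc4)cc3)cn2)cc1` is not yet measured. It stands to compound 3 as compound 2 stands to compound 1: methyl in place of hydrogen on an aromatic carbon, the same kind of change on a different core. Whether the methyl has the same effect on the core of compound 3 cannot be checked against anything measured, so the expectation rests on one step only.

For compound 4 in this assay the step expected is a 3.9-fold lower number from compound 3 to compound 4 (0.59 log units; beyond the scatter), somewhat smaller than the earlier one because a 4.9-fold lower number from compound 1 to compound 2 (0.69 log units; beyond the scatter) is a single observation and the core of compound 3 already sits at the weak end. The estimate for compound 4 is 9500 nM, with a range from 4000 nM to 25000 nM.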

Compound 4, half-maximal inhibitory concentration: 27900 nM
Beside the measured number, compound 4's estimate is 2.9-fold (0.47 log units) below it; measured number outside the range, above it.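

In the series, methyl in place of hydrogen on an aromatic carbon gives a 1.3-fold lower number from compound 3 to compound 4 (0.12 log units; within the scatter) in this assay and so does not repeat the size of the earlier step: the same change on two cores in this assay, a 4.9-fold lower number (0.69 log units; beyond the scatter) from compound 1 to compound 2 and a 1.3-fold lower number (0.12 log units; within the scatter) from compound 3 to compound 4, 3.7-fold (0.57 log units) apart, beyond the scatter of two such steps

The change therefore does not carry over at a fixed size between these two cores: phenyl to 4-methylphenyl gives a step beyond the scatter on the core of compound 1, but none that stands clear of the scatter on the core of compound 3. Going by these compounds alone, this does not show why the two cores differ, and it gives no rule for any further core, with only one pair on each core and each step resting on a single comparison.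

The compounds shown leave open whether another group in the same place, such as ethyl, methoxy, chlorine, an amine or a carboxylic acid, would also depend on the core in this way. They also leave open how either core would respond to a change on the benzenesulfonamide phenyl ring, which is the same in all four compounds.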